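The compounds below may be only part of what the source reports. "The series", "measured", "known", "first", "only" and "open" are said of these compounds alone.

Measured so far in a functional assay on K562 cells (Homo sapiens) for cytotoxicity, read by MTT assay; on this read-out higher numbers stand for an effect only at larger amounts of compound and lower numbers for an effect already at smaller amounts:
- compound 1 `CCCCCCCCCCCCCCCCCCCCCCCCc1cn([C@@H](CO)[C@H](O)[C@H](O)CCCCCCCCCCCCCC)nn1` gives > 50000 nM (a limit, not a number)
- compound 2 `CCCCCCCCCCCCC/C=C/[C@@H](O)[C@H](CO)n1cc(CCC)nn1` gives 13000 nM as a number
- compound 3 `CCCCCCCCCCCCCC[C@@H](O)[C@@H](O)[C@H](CO)n1cc(CCC)nn1` gives 14900 nM as a number

Compound 3 at 14900 nM and compound 2 at 13000 nM lie within the scatter of each other. Compound 1 offers no number for comparison, as its result is a limit (the limit of > 50000 nM in this assay, at which 1 of the 3 values shown sits). For the measured compounds named here, compound 3 therefore has only one numerical neighbour.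

Next is compound 4 `CCCCCCCCCCCCCC[C@@H](O)[C@@H](O)[C@H](CO)n1cc(CCCC)nn1`, which has methyl in place of hydrogen on a saturated chain carbon, three bonds along the chain from an aromatic carbon. The same difference reads as propyl to butyl. Going by the values given here, no two measured compounds differ in one place only, so no measured step gives the size of this change directly. In this assay, on these data alone, no step beyond the scatter is expected, and the direction remains open. The expected step runs a 1.2-fold lower number from compound 3 to compound 4 (0.09 log units; within the scatter) as an estimate only, and a small move the other way would not be surprising. Compound 4 is expected at 12000 nM with an estimated range of 6000 nM to 25000 nM in this assay when it is measured.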

Compound 4, half-maximal effective concentration: 14500 nM
Estimate against measurement, compound 4: 1.2-fold (0.08 log units) below; low and high end bracket the measured number.
By their numbers in this assay, from the lowest: compounds 2, 4 and 3 (each within the scatter of the next). At a limit, above all of these: compound 1.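

Propyl to butyl gives a 1.0-fold lower number from compound 3 to compound 4 (0.01 log units; within the scatter) in this assay, and this is the first reading of a single change in the series, made on a saturated chain carbon, three bonds along the chain from an aromatic carbon. For the compounds shown here, at this place, one added methyl does not separate the two compounds on this read-out, something the earlier compounds could not show, as no two of them differed in one place only. No measurement shown speaks to a cause for this result.

One step of a single carbon leaves open whether a longer chain such as octyl, or an amine or a carboxylic acid in place of butyl, would stay within the scatter of compound 3 in this assay or move clear of it. Compound 1 remains a limit at > 50000 nM and is no number, and it differs from the other compounds in more than one place, so it gives no reading of how far this chain can be extended.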